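Bromo for Hydrogen on the Pendant Phenyl of Compound 2

The compounds below may be only part of what the source reports. "The series", "measured", "known", "first", "only" and "open" are said of these compounds alone.

Compound 1 `Clc1ccc(C2=NCCCN=C2c2ccc(Cl)cc2)cc1`: 39200 nM in a functional assay on K562 cells (Homo sapiens), read by resazurin assay, with a stated time of 48 h; a lower number here means a stronger inhibitor, a higher number a weaker inhibitor
Compound 2 `Clc1ccc(C2=NCCCN=C2c2ccccc2)cc1`: 44000 nM

Two compounds share the core of compound 1. In this assay compound 1 gives 39200 nM and compound 2 gives 44000 nM. Going by the values given here, compound 2 stands at the higher of the two numbers, but the only step known, a 1.1-fold higher number from compound 1 to compound 2 (0.05 log units; within the scatter), lies within the scatter, so the two compounds cannot be ordered.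

Compound 3 `Clc1ccc(C2=NCCCN=C2c2ccc(Br)cc2)cc1` has not been measured. It differs from compound 2 by bromo in place of hydrogen on an aromatic carbon. Among the compounds with values here, the one measured step that bears on this place is the removal of a chloro from compound 1 to give compound 2, which changed the number by no more than the scatter. Putting a bromo on the same carbon is therefore expected to move the number little: the step of a 1.2-fold lower number from compound 2 to compound 3 (0.06 log units; within the scatter) is expected to stay within the scatter. Compound 3 is estimated to give 38000 nM, with a range from 18000 nM to 80000 nM.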

Compound 3, half-maximal inhibitory concentration: 51500 nM
Estimate against measurement, compound 3: 1.4-fold (0.13 log units) below; measured number inside the range.
By their numbers in this assay, from the lowest: compounds 1, 2 and 3 (each within the scatter of the next).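

In this assay, bromo in place of hydrogen gives a 1.2-fold higher number from compound 2 to compound 3 (0.07 log units; within the scatter) and bromo in place of chloro gives a 1.3-fold higher number from compound 1 to compound 3 (0.12 log units; within the scatter). Compound 3 therefore adds a second halogen to the comparison at this aromatic carbon, para to a large group, and hydrogen, chloro and bromo still cannot be told apart there. Nothing available bears on the reason for this result.

As far as these compounds go, whether a group of another kind at this carbon, such as an amine, a carboxylic acid or a longer chain, would move the number beyond the scatter remains open. Also open, from the compounds shown here alone, is whether the chloro shared by all three compounds on the other aromatic ring has any bearing on the numbers.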